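A few compounds are considered here, and "the series" means these few. Any claim that something is new, unique, unknown or untested is made for them only; others in the source may bear on it.

Of the compounds shown here, two of a shared core have been measured so far. Compound 1 `O=C(COc1ccc2cc(/C=C3/SC(=O)NC3=O)ccc2c1)Nc1ccc(Br)cc1F` gives 1900 nM in an assay on isolated protein for inhibition of histone deacetylase 4 (Homo sapiens), with a stated time of 1 h; a higher number here means a weaker inhibitor, a lower number a stronger inhibitor. Compound 2 `COc1cccc(NC(=O)COc2ccc3cc(/C=C4/SC(=O)NC4=O)ccc3c2)c1` gives 1600 nM in this assay; its number and that of compound 1 lie within the scatter of each other, so neither can be called the stronger inhibitor. Within the data shown here, the single measured step, a 1.2-fold lower number from compound 1 to compound 2 (0.07 log units; within the scatter), exchanged a phenyl carrying two halogens for one carrying a methoxy group and moved the number by no more than the scatter.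

Compound 3 `O=C(COc1ccc2cc(/C=C3/SC(=O)NC3=O)ccc2c1)Nc1ccc(Br)c(Br)c1` has not yet been measured. The change is 3,4-dibromophenyl in place of 3-methoxyphenyl on an amide-type nitrogen. This step bears directly on the measured one, since it again swaps the methoxyphenyl for a phenyl carrying two halogens, and that earlier swap changed little. A step no larger than the scatter is therefore expected, a 1.1-fold higher number from compound 2 to compound 3 (0.05 log units; within the scatter), in no firm direction. Compound 3 is estimated to give 1800 nM, with a likely range from 900 nM to 3600 nM.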

Compound 3, half-maximal inhibitory concentration: 4900 nM
Beside the measured number, compound 3's estimate is 2.7-fold (0.43 log units) below it, and the stated range ends below it.
By their numbers in this assay, from the lowest: compounds 2 and 1 (each within the scatter of the next); then compound 3.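

The group on the amide-type nitrogen can matter after all: in this assay, 3,4-dibromophenyl gives a 3.1-fold higher number from compound 2 to compound 3 (0.49 log units; beyond the scatter) and also a 2.6-fold higher number from compound 1 to compound 3 (0.41 log units; beyond the scatter), both modest but beyond the scatter. Carrying two halogens on the phenyl therefore does not settle the outcome, as 4-bromo-2-fluorophenyl stays within the scatter of 3-methoxyphenyl while 3,4-dibromophenyl does not. No measurement shown here accounts for this difference.

These three compounds cannot separate the effect of the second bromine from that of the halogens' places on the ring, which a phenyl carrying a single bromine would begin to address. On these data alone, it also remains open whether a phenyl carrying an amine or a carboxylic acid would bring the number below those of compound 2 and compound 1.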